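The source may report more compounds than this note shows. Statements on the series, on what has been measured and on what is new or still open speak of the compounds shown alone.

In an ADME assay on HEK293 cells (Homo sapiens) for cytotoxicity, read by MTT assay, with a stated time of 3 days (on this read-out higher numbers stand for weaker inhibition and lower numbers for stronger inhibition), compound 1, `COc1ccc(-c2cccc(O)c2)c(OC)c1`, gives 28 ug/mL. Compound 2, `COc1ccc(-c2cccc(N)c2)c(OC)c1`, gives 29.2 ug/mL in this assay. The two differ by amino in place of hydroxy on an aromatic carbon, and that change gave a 1.0-fold higher number from compound 1 to compound 2 (0.02 log units; within the scatter). Compound 3, `COc1ccc(-c2cccc(O)c2)cc1OC`, is built on a core that is put together from the same atoms as the core of compound 1 but joined differently; the difference between the two cores is not broken down here. In this assay compound 3 gives 23.1 ug/mL. Among the measured compounds shown here, compound 4, `COc1ccc(-c2cccc(N)c2)cc1OC`, has not been measured yet; it differs from compound 3 by amino in place of hydroxy on an aromatic carbon, the same change as the one from compound 1 to compound 2. For the measured compounds named here, since that earlier change stayed within the scatter, a step of about a 1.0-fold higher number from compound 3 to compound 4 (0.02 log units; within the scatter) is expected here too, resting on the single example given by compound 1 and compound 2 with a 1.0-fold higher number from compound 1 to compound 2 (0.02 log units; within the scatter). Compound 4 is therefore estimated at 24 ug/mL in this assay, most likely between 15 ug/mL and 38 ug/mL.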

Compound 4, half-maximal inhibitory concentration: 20 ug/mL
For compound 4 the middle estimate is 1.2-fold (0.08 log units) above the measured one; measured number inside the range.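

In this assay, putting amino in place of hydroxy on the second core gives a 1.2-fold lower number from compound 3 to compound 4 (0.06 log units; within the scatter). Set beside the first example, the change carries across these two cores with no difference that can be told from the scatter: the same change on two cores in this assay, a 1.0-fold higher number (0.02 log units; within the scatter) from compound 1 to compound 2 and a 1.2-fold lower number (0.06 log units; within the scatter) from compound 3 to compound 4, 1.2-fold (0.08 log units) apart, within the scatter of two such steps. Among the compounds shown here, this shows that the swap left the number within the scatter on both cores, but it rests on only two pairs and does not show that amino and hydroxy would match on other cores or in other assays.

The compounds shown leave open what other groups would do at this place on the ring, such as a carboxylic acid, a nitrile or an amide. As far as these compounds go, whether the two cores would respond alike to such groups also stays open.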